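A few compounds are considered here, and "the series" means these few. Any claim that something is new, unique, unknown or untested is made for them only; others in the source may bear on it.

In an ADME assay on Vero cells (Chlorocebus sabaeus) for cytotoxicity (a higher number here means that more compound is tolerated, a lower number that less compound is tolerated), compound 1 `Fc1ccc(-c2nc3ccc(Br)cn3c2-c2ccnc(NC3CCCC3)n2)cc1` stands at a limit of the assay, giving > 40000 nM. Compound 2 `Fc1ccc(-c2nc3ccc(NC4CCCC4)cn3c2-c2ccnc(NC3CCCC3)n2)cc1` also reaches only a limit in this assay, at > 40000 nM. Compound 3 `Fc1ccc(-c2nc3ccccn3c2-c2ccnc(NC3CCCC3)n2)cc1` likewise gives a limit in this assay, > 40000 nM. The steps among these three are therefore a step that the two limits leave unreadable from compound 1 to compound 2, a step that the two limits leave unreadable from compound 1 to compound 3 and a step that the two limits leave unreadable from compound 2 to compound 3, all unreadable because of the limit of > 40000 nM in this assay, at which 3 of the 3 values shown sit. Compound 4 `Fc1ccc(-c2nc3c(NC4CCCC4)cc(Br)cn3c2-c2ccnc(NC3CCCC3)n2)cc1` departs from compound 1 by cyclopentylamino in place of hydrogen on an aromatic carbon. The measured steps offer no readable size for any change on the shared core, so the expected step is a number no higher from compound 1 to compound 4 (the limit leaves the size open), none beyond the scatter. Compound 4 is estimated to give 40000 nM, within the range 20000 nM to 80000 nM, most likely again as a limit.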

Compound 4, half-maximal cytotoxic concentration: > 40000 nM
Compound 4: a limit, no number; the forecaster's own chance of this, stated with the estimate: 85%; the middle value lies on the limit itself.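

No size can be read for the step between compound 1 and compound 4, since both stand at a limit: the limit of > 40000 nM in this assay, at which 4 of the 4 values shown sit.
The compounds shown leave open where any of the four would reach its half-maximal cytotoxic concentration in this assay and whether any change on the shared core alters it.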